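The source may report more compounds than this note shows. Statements on the series, on what has been measured and on what is new or still open speak of the compounds shown alone.

In a functional assay on QG-56 cells (Homo sapiens) for antiproliferative activity (a higher number here means a weaker inhibitor, a lower number a stronger inhibitor), compound 1 (`COc1cccc(-c2cc([N+](=O)[O-])cc3cc(C(O)(c4ccc(C#N)cc4)c4cncn4C)oc23)c1`) gives 38.8 nM and compound 2 (`COc1ccc(C(O)(c2cc3cc([N+](=O)[O-])cc(-c4ccccc4)c3o2)c2cncn2C)cc1`) gives 4970 nM. Compound 3 (`Cn1cncc1[C@@](N)(c1ccc(C#N)cc1)c1cc2cc(C#N)cc(-c3cccc(C#N)c3)c2o1`) gives 2 nM, the lowest of the three numbers, with both gaps beyond the scatter. Compound 4 (`Cn1cncc1[C@@](N)(c1ccc(C#N)cc1)c1cc2cc(C#N)cc(-c3cccc(F)c3)c2o1`) differs from compound 3 in one place: fluoro in place of cyano on an aromatic carbon, meta to a large group, turning 3-cyanophenyl into 3-fluorophenyl (fluoro in place of cyano on an aromatic carbon). Within the data shown here, no measured pair shows this change, so no direct precedent exists. With compound 3 at 2 nM, the low end of the series, a small rise in this assay is expected, near the edge of the scatter. The estimated change is a 2.5-fold higher number from compound 3 to compound 4 (0.40 log units; beyond the scatter). For compound 4 the estimated value is 5 nM, with an expected range of 1.5 nM to 20 nM.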

Compound 4, half-maximal inhibitory concentration: 2 nM
Beside the measured number, compound 4's estimate is 2.5-fold (0.40 log units) above it, within the range that was stated.
By their numbers in this assay, from the lowest: compounds 3 and 4 (each within the scatter of the next); then compound 1; then compound 2.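

In this assay the 3-cyanophenyl group of compound 3 can become 3-fluorophenyl and the value holds (no change at the digits printed from compound 3 to compound 4 (within the scatter)). Among these compounds, the cyano group at this position, meta to a large group, is therefore not required for a low number, and fluoro serves equally well; no earlier pair isolated this position. Nothing available explains why the two groups match here.

Still open, going by these compounds, is whether a bare hydrogen at this carbon, with the rest of compound 3 unchanged, holds the value. Also open, on these data alone, is whether an amine or a carboxylic acid is accepted there.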